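Cytotoxicity notes: aryl swap from compound 1 to compound 4

The source may report more compounds than this note shows. Statements on the series, on what has been measured and on what is new or still open speak of the compounds shown alone.

Compound 1 `Cc1ccccc1-c1nn(-c2ccc(F)cc2F)cc1CNCCN1CCN(C)CC1` stands only at a limit in an ADME assay on Huh-7 cells (Homo sapiens) for cytotoxicity; on this read-out higher numbers stand for lower toxicity in this test and lower numbers for higher toxicity in this test: compound 1 gives > 20000 nM, which is an assay limit and not a number. Compound 2 `CCN(CC)CCCNCc1cn(-c2ccc(F)cc2F)nc1-c1ccccc1C` gives > 20000 nM, again a limit. Compound 3 `Cc1ccccc1-c1nn(-c2ccc(F)cc2F)cc1CNCCCCO` gives > 20000 nM, also a limit. The three measured steps, from compound 1 to compound 2 a step that the two limits leave unreadable from compound 1 to compound 2, from compound 1 to compound 3 a step that the two limits leave unreadable from compound 1 to compound 3 and from compound 2 to compound 3 a step that the two limits leave unreadable from compound 2 to compound 3, are all unreadable because of the limit of > 20000 nM in this assay, at which 3 of the 3 values shown sit.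

Compound 4 `CN1CCN(CCNCc2cn(-c3ccc(F)cc3F)nc2-c2ccc(C(F)(F)F)cc2)CC1` differs from compound 1 by 4-(trifluoromethyl)phenyl in place of 2-methylphenyl on an aromatic carbon. Within the data shown here, no measured step touches this aromatic carbon; all three change the chain end, so none bears directly on it. With every chain variant at the limit, compound 4 is expected to show no step beyond the scatter a number no higher from compound 1 to compound 4 (the limit leaves the size open) and most likely to sit at the limit again. Compound 4 is estimated at 20000 nM, range 8000 nM to 50000 nM.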

Compound 4, half-maximal cytotoxic concentration: 20000 nM
Compound 4: middle estimate and measured number agree at the digits printed, and the stated range covers the measured number.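

In this assay, this aromatic carbon now has its first reading: 4-(trifluoromethyl)phenyl in place of 2-methylphenyl gives a number no higher from compound 1 to compound 4 (the limit leaves the size open). Among these compounds, compound 4 gives 20000 nM, a number rather than a limit, so the larger aryl group brings no step that can be sized at this position. The size of this step, like that of the chain steps, cannot be read: the limit of > 20000 nM in this assay, at which 3 of the 4 values shown sit.

Still open, going by these compounds, is how 4-methylphenyl or 2-(trifluoromethyl)phenyl would read here, either of which would separate the place of the substituent from its identity. On these data alone, a carboxylic acid on this aryl ring is equally open.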